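The source may report more compounds than this note shows. Statements on the series, on what has been measured and on what is new or still open speak of the compounds shown alone.

Working notes on the series. All three measured compounds share the core of compound 1 `CC(=O)OCc1ccc2oc(=O)c(C(=O)Oc3cccc(Cl)c3)cc2c1` and differ only in the group on the carbonyl carbon. In a functional assay on HT-1080 cells (Homo sapiens), read by transwell migration, with a stated time of 24 h, tested at 0.1 uM (a lower number here means a stronger effect, a higher number a weaker effect of the compound at the concentration tested), compound 1 gives 95.2%. Compound 2 `CC(=O)OCc1ccc2oc(=O)c(C(=O)Sc3cccc(Cl)c3)cc2c1` gives 76.5% in this assay, and compound 3 `CC(=O)OCc1ccc2oc(=O)c(C(=O)Nc3cccc(Cl)c3)cc2c1` gives 79.6%. Compound 1 therefore stands highest of the three numbers: the step of a number 18.7 percentage points lower from compound 1 to compound 2 (beyond the scatter) and the step of a number 15.6 percentage points lower from compound 1 to compound 3 (beyond the scatter) are both beyond the scatter, whereas the step of a number 3.1 percentage points higher from compound 2 to compound 3 (within the scatter) stays within it.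

Compound 4 `O=C(Oc1cccc(Cl)c1)c1cc2ccccc2oc1=O` differs from compound 1 at another place: hydrogen in place of acetoxymethyl on an aromatic carbon. Among the compounds with values here, none of the measured steps touches this position; each of them exchanges the 3-chlorophenoxy partner on the carbonyl carbon and leaves the acetoxymethyl untouched, so no measured step bears directly on the change to compound 4. The measured steps only show that the read-out of the series moves by modest amounts when the carbonyl partner changes. Within the data shown here, with no precedent for removing the acetoxymethyl, the central expectation is that compound 4 stays close to compound 1, with a range widened downward to allow for an unseen effect. The expected step is a number 5.2 percentage points lower from compound 1 to compound 4 (within the scatter), which is not beyond the scatter. For compound 4 the estimate in this assay is 90%, within 70% to 102%.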

Compound 4, a percentage reported as activity, at one concentration (the size of the read-out at that concentration, not a potency): 52.4%
Estimate against measurement, compound 4: 37.6 percentage points above; measured number outside the range, below it.
By their numbers in this assay, from the lowest: compound 4; then compounds 2 and 3 (each within the scatter of the next); then compound 1.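

In this assay the acetoxymethyl position proves to matter: hydrogen in place of acetoxymethyl on the aromatic carbon gives a number 42.8 percentage points lower from compound 1 to compound 4 (beyond the scatter), a large step, whereas the exchanges of the carbonyl partner gave only modest ones. The change at this place, meta to a fused ring and para to a fused ring, therefore moves the read-out further than any step seen so far in the series, and it moves it toward a stronger effect at the concentration tested. Nothing at hand accounts for the size of this step or ties it to a particular part of the acetoxymethyl.

Going by these compounds, it remains open whether the full removal of the group is needed, or whether a methyl, a hydroxymethyl, an amine or a carboxylic acid at this place would give a number near that of compound 4 or near that of compound 1. On these data alone, it also remains open whether the (3-chlorophenyl)sulfanyl and (3-chlorophenyl)amino partners would shift the read-out in the same way on a core carrying hydrogen at this place.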